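From 3-chloro-4-methoxyphenyl to 1H-indol-6-yl

A few compounds are considered here, and "the series" means these few. Any claim that something is new, unique, unknown or untested is made for them only; others in the source may bear on it.

Of the compounds shown here, three have numbers so far in a functional assay on HeLa cells (Homo sapiens) for antiproliferative activity, read by CCK-8 assay, with a stated time of 72 h; on this read-out higher numbers stand for weaker inhibition and lower numbers for stronger inhibition. Compound 2 (`COc1ccc(-c2cncnc2-c2cc(OC)c(OC)c(OC)c2)cc1Cl`) gives 320 nM, the middle of the three. Compound 1 (`CCOC(=O)Oc1cc(-c2cncnc2-c2cc(OC)c(OC)c(OC)c2)ccc1OC`) stands higher at 650 nM, and compound 3 (`CCOc1ccc(-c2cncnc2-c2cc(OC)c(OC)c(OC)c2)cc1Cl`) stands lower at 90 nM.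

Compound 4 (`COc1cc(-c2ncncc2-c2ccc3cc[nH]c3c2)cc(OC)c1OC`) has not yet been measured. Its difference from compound 2 is 1H-indol-6-yl in place of 3-chloro-4-methoxyphenyl on an aromatic carbon. In words, 1H-indol-6-yl takes the place of 3-chloro-4-methoxyphenyl on an aromatic carbon of the shared core.

Among the compounds with values here, two measured steps touch this same aryl group. The first is a 2.0-fold lower number from compound 1 to compound 2 (0.31 log units; beyond the scatter), with chloro in place of (ethoxycarbonyl)oxy. The second is a 3.6-fold lower number from compound 2 to compound 3 (0.55 log units; beyond the scatter), with methyl in place of hydrogen on the saturated chain carbon bound to the oxygen. Both are modest, lie beyond the scatter and go towards lower numbers. Within the data shown here, neither exchanges the whole group, and no measured compound carries 1H-indol-6-yl, so these steps give only a rough guide to size and a weak one to direction.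

A modest move is expected, and the estimated step is a 2.1-fold lower number from compound 2 to compound 4 (0.33 log units; beyond the scatter), though a move the other way remains possible. The estimate for compound 4 is 150 nM, with an expected range of 25 nM to 900 nM.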

Compound 4, half-maximal inhibitory concentration: 770 nM
Beside the measured number, compound 4's estimate is 5.1-fold (0.71 log units) below it, and the stated range covers the measured number.
By their numbers in this assay, from the lowest: compound 3; then compound 2; then compounds 1 and 4 (each within the scatter of the next).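

In this assay, exchanging the whole 3-chloro-4-methoxyphenyl group for 1H-indol-6-yl gives a 2.4-fold higher number from compound 2 to compound 4 (0.38 log units; beyond the scatter), the only step shown at this position that goes towards a higher number. The two earlier steps were edits within the aryl group and both went lower, so this position does not respond in one direction to every change made there. The two groups have the same count of heavy atoms but differ in their rings and hetero atoms, and the entering group brings a hydrogen-bond donor, yet no measurement separates these differences, so the step cannot be assigned to any one of them.

The compounds shown leave open whether the hydrogen on the indole nitrogen matters to this step, and an indole carrying a methyl group on that nitrogen at the same place would test this directly. Also open, going by these compounds, is how far the trend from compound 2 to compound 3 extends on the chain bound to the oxygen, for which a propoxy group in place of the ethoxy group of compound 3 would be the next comparison.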